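Methoxy pattern on the benzamide: third methoxy added

This account rests on a few compounds, and the source may have more. Where it says the series, first, only, none or still open, it means among the compounds named here.

The series shares one core, varied only in the benzamide attached through the carbonyl. Compound 1 `CNc1nc(Nc2ccc(C)c(N)c2)ncc1C(=O)Nc1cc(NC(=O)c2ccccc2OC)ccc1C` carries the 2-methoxyphenyl and gives 1980 nM in a functional assay on K562 cells (Homo sapiens) for antiproliferative activity, read by CellTiter-Glo and CCK-8 assay, with a stated time of 72 h; a lower number here means a stronger inhibitor of growth, a higher number a weaker inhibitor of growth. Compound 2 `CNc1nc(Nc2ccc(C)c(N)c2)ncc1C(=O)Nc1cc(NC(=O)c2ccc(OC)cc2)ccc1C` carries the 4-methoxyphenyl and gives 610 nM. Compound 3 `CNc1nc(Nc2ccc(C)c(N)c2)ncc1C(=O)Nc1cc(NC(=O)c2cc(OC)cc(OC)c2)ccc1C` carries the 3,5-dimethoxyphenyl and gives 230 nM, the lowest of the three numbers; the steps of a 3.2-fold lower number from compound 1 to compound 2 (0.51 log units; beyond the scatter), an 8.6-fold lower number from compound 1 to compound 3 (0.93 log units; beyond the scatter) and a 2.7-fold lower number from compound 2 to compound 3 (0.42 log units; beyond the scatter) all run in the same direction, each beyond the scatter and each modest in size.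

Compound 4 `CNc1nc(Nc2ccc(C)c(N)c2)ncc1C(=O)Nc1cc(NC(=O)c2cc(OC)c(OC)c(OC)c2)ccc1C` differs from compound 3 by methoxy in place of hydrogen on an aromatic carbon, that is, 3,5-dimethoxyphenyl to 3,4,5-trimethoxyphenyl, the new group sitting ortho to two methoxy groups and para to a large group. Among the measured compounds shown here, no measured step adds a methoxy to an already substituted ring, so the bearing steps are indirect: compound 2 shows a single methoxy at that ring position gives 610 nM, weaker than compound 3, while each change so far toward more methoxy groups lowered the number. A step of about the scatter, in either direction, is therefore expected, a 1.2-fold lower number from compound 3 to compound 4 (0.06 log units; within the scatter). Compound 4 is estimated at 200 nM in this assay, with a range of 70 nM to 600 nM.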

Compound 4, concentration for 50% growth inhibition: 250 nM
The estimate for compound 4 lay 1.3-fold (0.10 log units) below the measured number; low and high end bracket the measured number.
By their numbers in this assay, from the lowest: compounds 3 and 4 (each within the scatter of the next); then compound 2; then compound 1.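

Methoxy in place of hydrogen at this carbon, ortho to two methoxy groups and para to a large group, gives no readable change in this assay, with a 1.1-fold higher number from compound 3 to compound 4 (0.04 log units; within the scatter). The 3,4,5-trimethoxyphenyl keeps the distance from the singly substituted rings, with a 2.4-fold lower number from compound 2 to compound 4 (0.39 log units; beyond the scatter) and a 7.9-fold lower number from compound 1 to compound 4 (0.90 log units; beyond the scatter), but compound 4 goes against the earlier run in which each change toward more methoxy groups lowered the number. No measured information on these compounds accounts for this flat step.

As far as these compounds go, whether this carbon accepts other groups equally remains open, for example a hydroxy, an amine, a fluorine or a longer chain such as ethoxy. Also open, from the compounds shown here alone, is whether a carboxylic acid there would stay level with compound 3.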